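A few compounds are considered here, and "the series" means these few. Any claim that something is new, unique, unknown or untested is made for them only; others in the source may bear on it.

Measured in a functional assay on HeLa cells (Homo sapiens) for cytotoxicity, read by WST assay, with a stated time of 48 h; on this read-out higher numbers stand for weaker inhibition and lower numbers for stronger inhibition:
Compound 1 `COc1cc(C(c2ccc(O)c(OC)c2)[C@H](C)[C@H](C)CO)ccc1O`: > 100000 nM
Compound 2 `COc1cc(C(c2ccc(O)c(OC)c2)[C@H](C)[C@@H](C)CO)ccc1O`: > 100000 nM

Both entries are limits of the assay, not numbers. Compound 2 gives > 100000 nM, which is a limit, so its place is fixed only by the limit of > 100000 nM in this assay, at which 2 of the 2 values shown sit. Compound 3 `COc1cc(C(c2ccc(O)c(OC)c2)[C@H](C)[C@@H](C)CF)ccc1O` carries one change from compound 2: fluoro in place of hydroxy on a saturated chain carbon, four bonds along the chain from two aromatic carbons. Among the measured compounds shown here, the one measured step, a step that the two limits leave unreadable from compound 1 to compound 2, reflects the fact that compounds 1 and 2 differ only in the configuration as drawn and leaves the hydroxy group in place, so it offers no size to carry over. Little change is therefore expected, with compound 3 probably staying at the limit, or with a small move toward stronger inhibition if a number appears. The expected step is an at least 1.2-fold lower number from compound 2 to compound 3 (0.09 log units; that floor lies within the scatter). For compound 3 the estimated value is 80000 nM, with an expected range from 25000 nM to 150000 nM.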

Compound 3, half-maximal inhibitory concentration: 34000 nM
Beside the measured number, compound 3's estimate is 2.4-fold (0.37 log units) above it; measured number inside the range.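

Fluoro in place of hydroxy on a saturated chain carbon, four bonds along the chain from two aromatic carbons, is the first change here to give a readable number in this assay, with an at least 2.9-fold lower number from compound 2 to compound 3 (0.46 log units; beyond the scatter). The wider swap of 1-(hydroxymethyl)ethyl for 1-(fluoromethyl)ethyl gives an at least 2.9-fold lower number from compound 1 to compound 3 (0.46 log units; beyond the scatter). Both steps start from a limit, so each size is only a floor: the limit of > 100000 nM in this assay, at which 2 of the 3 values shown sit.

Going by these compounds, it remains open whether the configuration at that chain carbon matters once fluoro is in place. On these data alone, it is also open how an amine or a longer chain would read at this position.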